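The source may hold more compounds than are shown below. What is called first, only, known or untested is meant among the compounds shown, and "the series" means these compounds.

Compound 2 `COC(=O)C1=C(C)N=C(C)/C(=C(\O)OC)C1c1ccccc1N` stands at the top of the two numbers obtained so far: in a functional assay (muscle tissue) with Cavia porcellus as the target (on this read-out lower numbers stand for an effect already at smaller amounts and higher numbers for an effect only at larger amounts of compound), compound 2 gives 39800 nM, whereas compound 1 `COC(=O)C1=C(C)N=C(C)/C(=C(\O)OC)C1c1c(Cl)cccc1Cl` gives 1.91 nM. Within the data shown here, the single measured step joins these two: a 21000-fold higher number from compound 1 to compound 2 (4.32 log units; beyond the scatter), the change there being 2-aminophenyl in place of 2,6-dichlorophenyl. Compound 3 `COC(=O)C1=C(C)N=C(C)/C(=C(\O)OC)C1c1ccccc1I` differs from compound 2 by one change, (iodo in place of amino on an aromatic carbon). Since iodo, like chloro, is a halogen, this change undoes part of what the measured step did, and the loss of the amino group is expected to move the number back toward that of compound 1, though only one halogen enters where 2,6-dichlorophenyl had two. Compound 3 is therefore expected at 20 nM in this assay, within 3 nM to 200 nM, an estimated shift of a 2000-fold lower number from compound 2 to compound 3 (3.30 log units; beyond the scatter).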

Compound 3, half-maximal effective concentration: 46.8 nM
For compound 3 the middle estimate is 2.3-fold (0.37 log units) below the measured one, and the stated range covers the measured number.
By their numbers in this assay, from the lowest: compound 1; then compound 3; then compound 2.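

In this assay, iodo in place of amino on the aromatic carbon wins back much of what the 2-aminophenyl group lost (an 850-fold lower number from compound 2 to compound 3 (2.93 log units; beyond the scatter)), so the group at this one place on the ring accounts for a large part of the earlier gap. A single iodo does not close that gap, however: 2-iodophenyl in place of 2,6-dichlorophenyl still leaves a large difference (a 25-fold higher number from compound 1 to compound 3 (1.39 log units; beyond the scatter)). Nothing measured here explains either step, so the reason for these shifts remains unknown.

The compounds shown leave open whether the remaining gap depends on the kind of halogen or on the second halogen of 2,6-dichlorophenyl. They also leave open how a single chloro, a methoxy or a nitro group would compare with iodo at this place.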